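This account rests on a few compounds, and the source may have more. Where it says the series, first, only, none or still open, it means among the compounds named here.

Working notes on the series, read in an ADME assay on BE(2)-C cells (Homo sapiens) for cytotoxicity, read by MTT assay, with a stated time of 20 h; a higher number here means that more compound is tolerated, a lower number that less compound is tolerated. Compound 1 (`CC(=O)n1c(C(=O)N2CCC(C(=O)N(C)Cc3ccccc3)CC2)cc2ccccc21`) gives > 50000 nM, which is a limit of the assay and not a number. Compound 2 (`CC(C)Cn1c(C(=O)N2CCC(C(=O)N(C)Cc3ccccc3)CC2)cc2ccccc21`) gives 58200 nM, and compound 3 (`CN(Cc1ccccc1)C(=O)C1CCN(C(=O)c2cc3ccccc3n2Cc2ccncc2)CC1`) gives 80300 nM. These two stand level, separated by a 1.4-fold higher number from compound 2 to compound 3 (0.14 log units; within the scatter). Compound 1 adds no size: it offers only a step that the limit leaves unreadable from compound 1 to compound 2 and a step that the limit leaves unreadable from compound 1 to compound 3.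

Compound 4 (`CN(Cc1ccccc1)C(=O)C1CCN(C(=O)c2cc3ccccc3n2Cc2ccc(C(F)(F)F)cc2)CC1`) carries the change (4-(trifluoromethyl)phenyl in place of pyridin-4-yl on a saturated chain carbon bound to an aromatic nitrogen), that is, 4-(trifluoromethyl)phenyl in place of pyridin-4-yl on a saturated chain carbon bound to an aromatic nitrogen. For the measured compounds named here, the one readable step at this place is the exchange of isopropyl for pyridin-4-yl, a 1.4-fold higher number from compound 2 to compound 3 (0.14 log units; within the scatter). On that basis, no step beyond the scatter is expected in this assay, in either direction. The step expected here is a 1.3-fold lower number from compound 3 to compound 4 (0.13 log units; within the scatter). The estimate for compound 4 is 60000 nM, with an expected range from 25000 nM to 120000 nM.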

Compound 4, half-maximal cytotoxic concentration: 90300 nM
For compound 4 the middle estimate is 1.5-fold (0.18 log units) below the measured one; measured number inside the range.
By their numbers in this assay, from the lowest: compounds 2, 3 and 4 (each within the scatter of the next).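

In this assay a ring of carbon only carrying trifluoromethyl can take the place of a six-membered aromatic ring with a hetero atom on a saturated chain carbon bound to an aromatic nitrogen, and the two compounds stay level, with a 1.1-fold higher number from compound 3 to compound 4 (0.05 log units; within the scatter) as the step. The comparison with the isopropyl group gives the same reading, with a 1.6-fold higher number from compound 2 to compound 4 (0.19 log units; within the scatter) as the step, so isopropyl, pyridin-4-yl and 4-(trifluoromethyl)phenyl do not separate at this place. The steps from compound 1 cannot be read, and its value is a limit: the limit of > 50000 nM in this assay, at which 1 of the 4 values shown sits.

No group shown at this place moves the number beyond the scatter. From the compounds shown here alone, whether an amine or a carboxylic acid on the benzyl ring, or a longer chain in place of the methylene, would do so stays open.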